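Replacing a nitro group by hydroxy in a diaryl methane

The compounds below may be only part of what the source reports. "The series", "measured", "known", "first", "only" and "open" are said of these compounds alone.

Of the compounds shown here, three have been measured in a functional assay on A549 cells (Homo sapiens) for cytotoxicity, read by XTT assay, with a stated time of 72 h; a higher number here means a weaker inhibitor, a lower number a stronger inhibitor. Compound 1 `CCn1ccc2cc(C(=O)c3cc(OC)c(OC)c(OC)c3)ccc21` gives 140 nM. Compound 2 `COc1ccc(Cc2ccc(OC)c(OC)c2OC)cc1[N+](=O)[O-]` gives only a limit, > 10000 nM, and no number. Compound 3 `COc1ccc(Cc2cc(OC)c(OC)c(OC)c2)cc1[N+](=O)[O-]` gives 26 nM, the lowest of the two numbers, with compound 1 as its nearest neighbour at a value a good deal higher, beyond the scatter. The limit of compound 2 is set out as the limit of > 10000 nM in this assay, at which 1 of the 3 values shown sits.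

The unmeasured compound 4 `COc1ccc(Cc2cc(OC)c(OC)c(OC)c2)cc1O` is derived from compound 3 by a single change: hydroxy in place of nitro on an aromatic carbon. Within the data shown here, no measured pair in this set differs in just one place, so the size of this step cannot be read from any comparison between measured compounds.

In this assay the author expects compound 4 to stay close to compound 3, with a step of a 1.3-fold lower number from compound 3 to compound 4 (0.11 log units; within the scatter) that may be no larger than the usual scatter, and any shift more likely towards a lower number than a higher one. The estimate for compound 4 in this assay is 20 nM, with a range from 5 nM to 80 nM.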

Compound 4, half-maximal inhibitory concentration: 28 nM
Estimate against measurement, compound 4: 1.4-fold (0.15 log units) below, within the range that was stated.
By their numbers in this assay, from the lowest: compounds 3 and 4 (each within the scatter of the next); then compound 1. At a limit, above all of these: compound 2.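

Among these compounds, this step is the first in the set that can be read between two measured compounds differing in one place: in this assay, hydroxy in place of nitro on an aromatic carbon, ortho to a methoxy group, gives a 1.1-fold higher number from compound 3 to compound 4 (0.03 log units; within the scatter). At this position, therefore, the nitro group is not required for a value in this range, since compound 3 and compound 4 stand within the scatter of each other even though the entering group has fewer heavy atoms and brings a hydrogen-bond donor that the nitro group lacks. Nothing among the measurements shown bears on why the two groups give such similar values.

The compounds shown leave open whether an amine, a carboxylic acid or a fluorine at this same position would also give a value close to those of compound 3 and compound 4. They also leave open whether hydroxy and nitro would stand as close together in a compound with a different arrangement of methoxy groups on the other ring.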